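From butyl to 3-methoxypropyl on a shared core

This account rests on a few compounds, and the source may have more. Where it says the series, first, only, none or still open, it means among the compounds named here.

Compound 1 `COc1cc(OC)c2c(c1)C(C(O)c1ccc(O)cc1)OC2=O` and compound 2 `CCCCOc1ccc(C(O)C2OC(=O)c3c(OC)cc(OC)cc32)cc1` share one core and differ at a single oxygen on an aromatic ring. In an ADME assay on RAW264.7 cells (Mus musculus) for cytotoxicity, read by MTT assay, with a stated time of 24 h, in the absence of a further agent (a higher number here means a weaker inhibitor, a lower number a stronger inhibitor), compound 1 gives > 40000 nM, which is a limit of the assay and not a number. Compound 2 gives > 40000 nM, also only a limit. Compound 2 therefore has no exact value, and the picture so far is simple: the limit of > 40000 nM in this assay, at which 2 of the 2 values shown sit.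

Compound 3 `COCCCOc1ccc(C(O)C2OC(=O)c3c(OC)cc(OC)cc32)cc1` alters only the end of the butyl chain of compound 2: methoxy in place of methyl on a saturated chain carbon, three bonds along the chain from an oxygen on an aromatic ring. Put another way, butyl becomes 3-methoxypropyl.

Among the compounds with values here, the one measured step that bears on this change is a step that the two limits leave unreadable from compound 1 to compound 2, in which butyl replaced hydrogen on that oxygen. It offers no size to carry forward, and it shows no movement away from the limit. No step beyond the usual scatter is expected in this assay, and no direction can be favoured. The expected step is a step that the limit leaves unreadable from compound 2 to compound 3. For compound 3 the estimated value is 45000 nM, with an expected range of 25000 nM to 90000 nM, and the assay may well report only a limit again.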

Compound 3, half-maximal inhibitory concentration: > 40000 nM
Compound 3: a limit, no number; the forecaster's own chance of this, stated with the estimate: 85%; the middle value is on the limit's open side.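

Compound 3 also gives only a limit of the assay and not a number, so no step among compound 1, compound 2 and compound 3 can be read in this assay: the limit of > 40000 nM in this assay, at which 3 of the 3 values shown sit.

The compounds shown leave open whether hydrogen, butyl and 3-methoxypropyl on an oxygen on an aromatic ring differ at all here.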